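Swapping (1-Acetylpiperidin-4-yl)carbonyl for Methylcarbamoyl

The source may report more compounds than this note shows. Statements on the series, on what has been measured and on what is new or still open speak of the compounds shown alone.

In an assay on IM-9 cells for displacement of a labelled ligand from Substance-P receptor (Homo sapiens), read by scintillation counting, with a stated time of 30 min (on this read-out higher numbers stand for weaker inhibition and lower numbers for stronger inhibition), compound 1 `CCc1ccccc1[C@H]1CN(C(=O)C2CCN(C(C)=O)CC2)CC[C@@H]1C(=O)N(C)Cc1cc(C(F)(F)F)cc(C(F)(F)F)c1` gives 0.064 nM. Compound 2 `CC(=O)N1CCC(C(=O)N2CC[C@H](C(=O)N(C)Cc3cc(C(F)(F)F)cc(C(F)(F)F)c3)[C@@H](c3ccc(F)cc3C)C2)CC1` gives 0.047 nM in this assay, and the step of a 1.4-fold lower number from compound 1 to compound 2 (0.13 log units; within the scatter) places the two numbers together. Compound 2 thus gives the lowest of the two numbers shown, with compound 1 inside the usual scatter of it. Compound 3 `CNC(=O)N1CC[C@H](C(=O)N(C)Cc2cc(C(F)(F)F)cc(C(F)(F)F)c2)[C@@H](c2ccc(F)cc2C)C1` differs from compound 2 in methylamino in place of 1-acetylpiperidin-4-yl on a carbonyl carbon. Going by the values given here, no measured step touches this carbonyl, so nothing shows the size or direction to expect. The expected step is therefore set wide, at a 6.4-fold higher number from compound 2 to compound 3 (0.81 log units; beyond the scatter). Compound 3 is estimated to give 0.3 nM, between 0.05 nM and 2 nM.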

Compound 3, half-maximal inhibitory concentration: 0.048 nM
The estimate for compound 3 lay 6.3-fold (0.80 log units) above the measured number, and the stated range ends above it.
By their numbers in this assay, from the lowest: compounds 2, 3 and 1 (each within the scatter of the next).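

Swapping 1-acetylpiperidin-4-yl for methylamino on this carbonyl carbon gives a 1.0-fold higher number from compound 2 to compound 3 (0.01 log units; within the scatter) in this assay. The six-membered ring and its acetyl group can therefore go without any reading change in this assay, and a far smaller group serves equally well here. Nothing measured explains why the number holds.

As far as these compounds go, it remains open whether the hydrogen on the methylamino nitrogen matters, which dimethylamino would test. From the compounds shown here alone, it is also open whether any group at this place moves the number, such as a longer chain like hexylamino or a carboxylic acid.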